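This account rests on a few compounds, and the source may have more. Where it says the series, first, only, none or still open, it means among the compounds named here.

Of the compounds shown here, two built on one shared core have so far been measured in a functional assay on HCT-116 cells (Homo sapiens) for antiproliferative activity, read by MTT assay, with a stated time of 48 h; on this read-out higher numbers stand for weaker inhibition and lower numbers for stronger inhibition. Compound 1 `N#CC1=C(N)Oc2c(N)cc3nc4ccccc4nc3c2C12C(=O)N(Cc1cnnn1-c1ccccc1Br)c1ccccc12` carries a 2-bromophenyl on an aromatic nitrogen, and in this assay compound 1 gives 12400 nM. Compound 2 `Cc1ccc(Cl)cc1-n1nncc1CN1C(=O)C2(C(C#N)=C(N)Oc3c(N)cc4nc5ccccc5nc4c32)c2ccccc21` carries a 5-chloro-2-methylphenyl there instead, and in this assay compound 2 gives 37200 nM. Among the measured compounds shown here, compound 2 thus stands highest of the two numbers, with a 3.0-fold higher number from compound 1 to compound 2 (0.48 log units; beyond the scatter) separating it from its only neighbour. Compound 3 `N#CC1=C(N)Oc2c(N)cc3nc4ccccc4nc3c2C12C(=O)N(Cc1cnnn1-c1ccc([N+](=O)[O-])cc1[N+](=O)[O-])c1ccccc12` differs from compound 2 by 2,4-dinitrophenyl in place of 5-chloro-2-methylphenyl on an aromatic nitrogen. For the measured compounds named here, the single measured step that bears on this change, the swap of one aryl group for another on the same aromatic nitrogen, is a 3.0-fold higher number from compound 1 to compound 2 (0.48 log units; beyond the scatter), a modest one. Going by the values given here, no measured step involves a nitro group, so the expectation is wide. Compound 3 is expected to land near compound 2, a 1.5-fold lower number from compound 2 to compound 3 (0.17 log units; within the scatter), estimated at 25000 nM with a range from 7000 nM to 90000 nM.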

Compound 3, half-maximal inhibitory concentration: 23900 nM
Compound 3: the middle estimate sits 1.0-fold (0.02 log units) above what was measured; low and high end bracket the measured number.
By their numbers in this assay, from the lowest: compounds 1, 3 and 2 (each within the scatter of the next, the first and the last beyond it).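

Placing 2,4-dinitrophenyl on the aromatic nitrogen gives, in this assay, a 1.6-fold lower number from compound 2 to compound 3 (0.19 log units; within the scatter) and a 1.9-fold higher number from compound 1 to compound 3 (0.28 log units; within the scatter), so this aryl group cannot be told apart from either of the two aryl groups measured before it. The earlier step (a 3.0-fold higher number from compound 1 to compound 2 (0.48 log units; beyond the scatter)) is thus now spanned by a third aryl group that lies within the scatter of both ends, and a group with hydrogen-bond acceptors, which 5-chloro-2-methylphenyl lacks, leaves the number in the same range. No evidence is available that explains why these numbers lie so close together.

The compounds shown carry only substituted phenyl groups here, leaving open what an unsubstituted phenyl, a benzyl group or a butyl chain would give at this position. They also leave open whether an amine or a carboxylic acid on the phenyl ring would move the number outside this range.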